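The compounds below may be only part of what the source reports. "The series", "measured", "known", "first", "only" and "open" are said of these compounds alone.

Working notes on the series, step to compound 4. Compound 3, `C=C[C@@](C)(/C=C/c1ccc(-c2ccc(Cl)cc2)cc1)CCC=C(C)C`, gives > 36600 nM in a functional assay on SEM cells (Homo sapiens) for cytotoxicity, with a stated time of 72 h (on this read-out lower numbers stand for an effect already at smaller amounts and higher numbers for an effect only at larger amounts of compound), and this is a limit of the assay, not a number. Compound 1, `C=C[C@@](C)(/C=C/c1ccc(Nc2ccc(OC)cc2)cc1)CCC=C(C)C`, gives > 36600 nM, again a limit. Compound 2, `C=C[C@@](C)(/C=C/c1ccc(Nc2ccc(Cl)c(F)c2)cc1)CCC=C(C)C`, gives > 36600 nM, also a limit. All three measured compounds therefore share one reading: the limit of > 36600 nM in this assay, at which 3 of the 3 values shown sit.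

Compound 4, `C=C[C@@](C)(/C=C/c1ccc(-c2ccc(Cl)c(Cl)c2)cc1)CCC=C(C)C`, differs from compound 3 in a single place: chloro in place of hydrogen on an aromatic carbon. Seen one bond further out, 4-chlorophenyl becomes 3,4-dichlorophenyl.

For the measured compounds named here, three measured steps bear on this change, and none has a readable size: a step that the two limits leave unreadable from compound 1 to compound 2, a step that the two limits leave unreadable from compound 1 to compound 3 and a step that the two limits leave unreadable from compound 2 to compound 3. None of them gives a size to carry over, so no step beyond the scatter is expected in this assay, in either direction. The most likely outcome is another limit rather than a number. The expected change is a number no higher from compound 3 to compound 4 (the limit leaves the size open). For compound 4 the estimated value is 36600 nM, with an expected range from 15000 nM to 80000 nM.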

Compound 4, half-maximal effective concentration: > 36600 nM
Compound 4: only a limit was reported (the forecaster's own chance of this, stated with the estimate: 70%); the middle value lies on the limit itself.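

In this assay compound 4 gives > 36600 nM, a limit and not a number, so its steps from compound 1, compound 2 and compound 3 cannot be read. The series stays at one reading: the limit of > 36600 nM in this assay, at which 4 of the 4 values shown sit.

The compounds shown leave open what any of the four would give as a number in this assay, and whether the changes between them matter there.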